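The compounds below may be only part of what the source reports. "The series", "measured", "known", "first", "only" and "open" are said of these compounds alone.

Working notes on the series. In an assay on cells (Hepatocyte) for inhibition of glucokinase regulatory protein (Mus musculus), with stated times of 20 min and 40 min (on this read-out lower numbers stand for an effect already at smaller amounts and higher numbers for an effect only at larger amounts of compound), compound 1 `CC#C[C@H]1CN(S(=O)(=O)c2ccc(N)nc2)CCN1c1ccc(C(O)(COC)C(F)(F)F)cc1` gives 202 nM. Compound 2 `CC#C[C@H]1CN(S(=O)(=O)c2ccc(N)nc2)CCN1c1ccc([S+](C)[O-])cc1` gives only a limit of this assay, > 12500 nM (the limit of > 12500 nM in this assay, at which 1 of the 3 values shown sits). Compound 3 `CC#C[C@H]1CN(S(=O)(=O)c2ccc(N)nc2)CCN1c1ccc(S(=O)(=NC)C(F)(F)F)cc1` gives 2060 nM, the highest of the two numbers on hand; its nearest neighbour is compound 1, with a 10-fold higher number from compound 1 to compound 3 (1.01 log units; beyond the scatter). The other steps are an at least 61-fold higher number from compound 1 to compound 2 (1.79 log units; beyond the scatter) and an at least 6.0-fold lower number from compound 2 to compound 3 (0.78 log units; beyond the scatter).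

Compound 4 `CC#C[C@H]1CN(S(=O)(=O)c2ccc(N)nc2)CCN1c1ccc([C@](O)(CO)C(F)(F)F)cc1` is next to be measured in this assay. The change from compound 3: a group of 8 heavy atoms (3 carbon, 2 oxygen, 3 fluorine; no ring) in place of a group of 8 heavy atoms (2 carbon, 1 nitrogen, 1 oxygen, 3 fluorine, 1 sulfur; no ring), on an aromatic carbon. The step that bears on it is a 10-fold higher number from compound 1 to compound 3 (1.01 log units; beyond the scatter), which removed a trifluoromethyl-bearing carbinol from the aromatic carbon; compound 4 puts a trifluoromethyl-bearing carbinol back at that place, so the step is expected to run in the reverse direction, with a lower number and a size of the same order, that is a 6.9-fold lower number from compound 3 to compound 4 (0.84 log units; beyond the scatter). Compound 4 is therefore estimated at 300 nM in this assay, with a range from 110 nM to 850 nM.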

Compound 4, half-maximal effective concentration: 98 nM
Compound 4: the middle estimate sits 3.1-fold (0.49 log units) above what was measured; the measured number lies below the stated range.
By their numbers in this assay, from the lowest: compound 4; then compound 1; then compound 3. At a limit, above all of these: compound 2.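

In this assay, going by these compounds alone, the 1,2-dihydroxy-1-(trifluoromethyl)ethyl group on this aromatic carbon gives the lowest number so far, with a 21-fold lower number from compound 3 to compound 4 (1.32 log units; beyond the scatter), so this position responds strongly to which of these groups it carries. The methyl ether of compound 1 is not needed at the chain end, since the free hydroxyl gives a 2.1-fold lower number from compound 1 to compound 4 (0.31 log units; beyond the scatter), although this step is modest and compound 4 also has a defined stereocentre at the carbinol carbon that compound 1 lacks. The step of an at least 120-fold lower number from compound 2 to compound 4 (2.10 log units; beyond the scatter) is only a bound, as compound 2 stands at a limit: the limit of > 12500 nM in this assay, at which 1 of the 4 values shown sits.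

The compounds shown leave open how much of the step from compound 1 belongs to the stereocentre and how much to the methyl group. They also leave open whether an amine or a carboxylic acid at the chain end would hold the number of compound 4.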